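Adding a methylsulfanylphenyl group to the core of compound 3

The source may report more compounds than this note shows. Statements on the series, on what has been measured and on what is new or still open speak of the compounds shown alone.

Three close relatives have been measured in an assay on isolated protein for inhibition of Ca2+/calmodulin-dependent protein kinase II (CaM kinase II) (Rattus norvegicus), tested at 30 uM; a higher number here means more inhibition at the concentration tested (going by the name of the read-out), a lower number less inhibition. Compound 1 `Fc1ccc(Sc2ncnc3[nH]cnc23)cc1` gives 0%, compound 2 `Cn1cnc2c(Sc3ccccc3)ncnc21` gives 8%, and compound 3 `Cn1cnc2c(Sc3ccc(F)cc3)ncnc21` gives 5%. Compound 3 thus stands second highest of the three, yet all three lie within the scatter of one another. The two known steps, a number 5 percentage points higher from compound 1 to compound 3 (within the scatter) and a number 3 percentage points lower from compound 2 to compound 3 (within the scatter), are both small. Compound 4 `CSc1ccc(-c2nc3c(Sc4ccc(F)cc4)ncnc3n2C)cc1` differs from compound 3 by 4-(methylsulfanyl)phenyl in place of hydrogen on an aromatic carbon. Among the measured compounds shown here, no measured step involves such an entering group, so the known steps give no direct guidance. Compound 4 is therefore estimated at 15% in this assay, within 0% to 40%, a step of a number 10 percentage points higher from compound 3 to compound 4 (within the scatter) expected to be modest.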

Compound 4, a percentage reported as inhibition, at one concentration (the size of the read-out at that concentration, not a potency): 7%
Compound 4: the middle estimate sits 8 percentage points above what was measured, within the range that was stated.
By their numbers in this assay, from the lowest: compounds 1, 3, 4 and 2 (each within the scatter of the next).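

Compound 4 alone carries a substituent on the aromatic carbon between two ring nitrogen atoms, and in this assay placing 4-(methylsulfanyl)phenyl there gives a number 2 percentage points higher from compound 3 to compound 4 (within the scatter). This shows that the position accepts an aromatic ring of this size without a step beyond the scatter. No evidence on hand accounts for this result. As far as these compounds go, whether a smaller group at this carbon, such as an amine or a carboxylic acid, would give a step beyond the scatter stays open. So does the effect of a plain phenyl there.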